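Bromo in Place of Methyl on the Benzyl Ether

The source may report more compounds than this note shows. Statements on the series, on what has been measured and on what is new or still open speak of the compounds shown alone.

Measured compounds:
Compound 1, `COc1ccc2c(=O)c(-c3cc(OC)c(OC)cc3OC)coc2c1`, 2040 nM
Compound 2, `COc1cc(OC)c(-c2coc3cc(OCc4ccccc4C)ccc3c2=O)cc1OC`, 1860 nM

In a functional assay on HepG2 cells (Homo sapiens) for antiproliferative activity, read by MTT assay, with a stated time of 24 h (on this read-out lower numbers stand for stronger inhibition and higher numbers for weaker inhibition), compound 1 gives 2040 nM and compound 2 gives 1860 nM. For the measured compounds named here, the one measured step, a 1.1-fold lower number from compound 1 to compound 2 (0.04 log units; within the scatter), sits within the scatter, so the two compounds cannot be ordered. Compound 2 holds the lowest of the two numbers, but its nearest neighbour, compound 1, lies within the scatter of it.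

Compound 3, `COc1cc(OC)c(-c2coc3cc(OCc4ccccc4Br)ccc3c2=O)cc1OC`, is not yet measured. It differs from compound 2 by bromo in place of methyl on an aromatic carbon. Going by the values given here, no measured step touches this kind of change: the only step, from compound 1 to compound 2, adds the whole 2-methylphenyl group and says nothing about swapping its methyl for bromo. On that basis the step of a 1.1-fold lower number from compound 2 to compound 3 (0.04 log units; within the scatter) is expected to stay within the scatter, in no clear direction. Compound 3 is therefore estimated at 1700 nM in this assay, with a range from 700 nM to 4200 nM that allows for the absence of any guiding step.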

Compound 3, half-maximal inhibitory concentration: 2180 nM
Compound 3: middle estimate off by 1.3-fold (0.11 log units), on the low side, and the stated range covers the measured number.
By their numbers in this assay, from the lowest: compounds 2, 1 and 3 (each within the scatter of the next).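

In this assay, for the compounds shown here, the exchange of methyl for bromo, on an aromatic carbon ortho to a large group, gives a 1.2-fold higher number from compound 2 to compound 3 (0.07 log units; within the scatter) and is the first reading of a change at this place on the ring, where the two groups cannot be told apart. The whole 2-bromobenzyl group in place of hydrogen gives a 1.1-fold higher number from compound 1 to compound 3 (0.03 log units; within the scatter) and so behaves like the 2-methylbenzyl group before it, since neither the 2-methylphenyl nor the 2-bromophenyl group separates its compound from compound 1 in this read-out. No measurement is at hand that would help to interpret these readings.

The compounds shown leave open whether any group on this aromatic carbon can move the number beyond the scatter, for instance an amine or a carboxylic acid in place of methyl or bromo. Going by these compounds alone, they also leave open whether a longer chain between the ether oxygen and the aromatic ring would separate such a compound from compound 1, since all three numbers so far lie within the scatter of one another.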